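This account rests on a few compounds, and the source may have more. Where it says the series, first, only, none or still open, it means among the compounds named here.

Working notes on the series. All three compounds share the core of compound 1 `CON(Cc1cccs1)C(=O)COc1ccc(C)cc1`, in which an amide-type nitrogen carries a carbonyl carbon, a saturated chain carbon and one varied group. In an assay on HEK293 cells for agonist activity at transient receptor potential cation channel subfamily M member 8 (Homo sapiens), read by fluorescence and calcium flux, with a stated time of 15 min (on this read-out lower numbers stand for an effect already at smaller amounts and higher numbers for an effect only at larger amounts of compound), compound 1 gives 10 nM. For the measured compounds named here, compound 2 `Cc1ccc(OCC(=O)N(Cc2cccs2)c2cnn(C)c2)cc1` carries 1-methyl-1H-pyrazol-4-yl in place of methoxy on that nitrogen; in this assay compound 2 gives 63000 nM, the highest number of the two measured so far, and the step of a 6300-fold higher number from compound 1 to compound 2 (3.80 log units; beyond the scatter) lies far beyond the scatter. Compound 3 `Cc1ccc(OCC(=O)N(Cc2cccs2)c2cnccn2)cc1` is not yet measured; it differs from compound 2 by pyrazin-2-yl in place of 1-methyl-1H-pyrazol-4-yl on an amide-type nitrogen, so one aromatic hetero ring stands in for another at the same nitrogen. Going by the values given here, the single measured step, from compound 1 to compound 2, sets a small group against a ring and does not cover a ring-for-ring exchange, so no direct precedent exists; what the data show is that a ring at this nitrogen goes with the high number of compound 2. The step of a 1.3-fold lower number from compound 2 to compound 3 (0.10 log units; within the scatter) is therefore expected to stay within or near the scatter, in no firm direction. Compound 3 is estimated at 50000 nM in this assay, with a range from 10000 nM to 200000 nM.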

Compound 3, half-maximal effective concentration: 1240 nM
Compound 3: middle estimate off by 40-fold (1.61 log units), on the high side; the whole stated range lies above it.
By their numbers in this assay, from the lowest: compound 1; then compound 3; then compound 2.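

In this assay the exchange of one aromatic hetero ring for another on the amide-type nitrogen is far from neutral: although both groups have the same counts of heavy atoms, hetero atoms and hydrogen-bond acceptors, pyrazin-2-yl in place of 1-methyl-1H-pyrazol-4-yl gives a 51-fold lower number from compound 2 to compound 3 (1.71 log units; beyond the scatter) and lies well outside the usual variation, so the position responds to which ring is present and not only to whether a ring is present. A ring on this nitrogen is therefore not tied to a number as high as that of compound 2, yet pyrazin-2-yl in place of methoxy still gives a 120-fold higher number from compound 1 to compound 3 (2.09 log units; beyond the scatter), leaving both ring-bearing compounds clearly separated from compound 1. The data shown offer no independent measurement that would explain the difference between the two rings.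

The compounds shown leave open whether the gap between the two rings follows ring size, the methyl group of the five-membered ring or the arrangement of the hetero atoms. Also open, as far as these compounds go, is how an ethoxy group or a longer alkoxy chain on this nitrogen would compare with the methoxy group of compound 1.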